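Isobutyl to tert-butyl on the shared core

The compounds below may be only part of what the source reports. "The series", "measured", "known", "first", "only" and "open" are said of these compounds alone.

Values measured in a functional assay on K562 cells (Homo sapiens) for inhibition (on this read-out lower numbers stand for stronger inhibition and higher numbers for weaker inhibition), so far:
- compound 1 `CCCCCC(=O)OC1C(C(O)CO)OC2OC(C)(C)OC21` gives 1200000 nM
- compound 2 `CC(C)CC(=O)OC1C(C(O)CO)OC2OC(C)(C)OC21` gives 1000000 nM

Within the data shown here, compound 2 stands at 1000000 nM in this assay and cannot be separated from the only other measured compound: the step is a 1.2-fold lower number from compound 1 to compound 2 (0.08 log units; within the scatter) and gives no order between the two.

Compound 3 `CC1(C)OC2OC(C(O)CO)C(OC(=O)C(C)(C)C)C2O1` remains unmeasured. It has tert-butyl in place of isobutyl on a carbonyl carbon and the two structures have the same atoms joined differently. Among the measured compounds shown here, no measured compound carries tert-butyl, so the change itself has not been tested.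

For the measured compounds named here, one measured step bears on it, as the only other exchange of one chain for another: a 1.2-fold lower number from compound 1 to compound 2 (0.08 log units; within the scatter) with isopropyl in place of butyl on a saturated chain carbon bound to a carbonyl carbon. This single small step is thin evidence, but it gives no reason to expect a step beyond the scatter in this assay and no direction. The estimated step is no change at the digits printed from compound 2 to compound 3 (within the scatter) and thus no real change. Compound 3 is expected at 1000000 nM within an estimated range of 500000 nM to 2000000 nM as the working figure.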

Compound 3, half-maximal inhibitory concentration: 1500000 nM
The estimate for compound 3 lay 1.5-fold (0.18 log units) below the measured number, and the stated range covers the measured number.
By their numbers in this assay, from the lowest: compounds 2, 1 and 3 (each within the scatter of the next).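

In this assay, tert-butyl in place of isobutyl on the carbonyl carbon gives a 1.5-fold higher number from compound 2 to compound 3 (0.18 log units; within the scatter), and tert-butyl in place of pentyl at the same place gives a 1.3-fold higher number from compound 1 to compound 3 (0.10 log units; within the scatter). Neither exchange gives an order, so tert-butyl now joins pentyl and isobutyl as a third chain that cannot be separated from the others on this read-out, and the position shows no step beyond the scatter across these three compounds. Nothing available accounts for this lack of separation.

Going by these compounds, whether a group of another kind on this carbonyl carbon, such as a phenyl ring, an aminomethyl group or a carboxylic acid, would give a step beyond the scatter remains open. All three compounds share the same core and differ only in a saturated carbon chain, so they say nothing about changes elsewhere on the core, or about whether any compound in this series can reach a clearly lower number in this assay.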